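Shortening a Saturated Chain on an Amide Nitrogen

The source may hold more compounds than are shown below. What is called first, only, known or untested is meant among the compounds shown, and "the series" means these compounds.

Two amides share one core and differ only in the saturated chain on the amide nitrogen. Compound 1 `CCCCCCNC(=O)/C=C/c1ccccc1` carries a hexyl chain, compound 2 `CCCCCCCCCCCCCCCCNC(=O)/C=C/c1ccccc1` a much longer one. In a functional assay on the whole organism for inhibition, with Brassica rapa subsp. chinensis as the target, with a stated time of 3 days, tested at 100 ppm (a higher number here means more inhibition of growth at the concentration tested, a lower number less inhibition of growth), compound 1 gives 82%. In this assay compound 2 gives 75%. Compound 2 stands lowest of the two numbers, but its nearest neighbour, compound 1, sits only a number higher that lies within the scatter, so the two read alike.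

Compound 3 `CCCCCCCCCCCCNC(=O)/C=C/c1ccccc1` has not yet been measured. It differs from compound 2 by hydrogen in place of butyl on a saturated chain carbon, ten or more bonds along the chain from an amide-type nitrogen; the same difference, cut one bond further out, reads pentyl to methyl. Within the data shown here, no step between measured compounds is known. Compound 1 at 82% and compound 2 at 75% lie within the scatter of each other, and the chain of compound 3 is shorter than that of compound 2 and longer than that of compound 1. The expected step from compound 2 to compound 3 a number 3 percentage points higher from compound 2 to compound 3 (within the scatter) is therefore none beyond the scatter. Compound 3 is estimated at 78%, with a range from 64% to 90%.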

Compound 3, percent growth inhibition at one concentration: 32%
Estimate against measurement, compound 3: 46 percentage points above; the whole stated range lies above it.
By their numbers in this assay, from the lowest: compound 3; then compounds 2 and 1 (each within the scatter of the next).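

In this assay, the change of hydrogen in place of butyl on a saturated chain carbon, ten or more bonds along the chain from an amide-type nitrogen, is a large one: a number 43 percentage points lower from compound 2 to compound 3 (beyond the scatter). Measured from the other side, with hexyl in place of hydrogen on a saturated chain carbon, six bonds along the chain from an amide-type nitrogen, the step is also large: a number 50 percentage points lower from compound 1 to compound 3 (beyond the scatter). The two earlier compounds read alike and could have suggested that chain length on the amide nitrogen hardly matters, but the intermediate chain of compound 3 lies beyond the scatter below both its shorter and its longer neighbour, so the number does not follow chain length in one direction, and nothing available bears on why this chain falls so low.

Whether the low number belongs to the chain of compound 3 alone or to a wider stretch of chain lengths stays open, as the compounds shown offer no chain of any other length on the shared core. Equally open, from the compounds shown here alone, is how a branched chain, or a chain ending in a carboxylic acid or an amine, would read at this position.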